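The compounds below may be only part of what the source reports. "The series", "measured", "known", "first", "only" and "open" are said of these compounds alone.

Compound 1 `CCOC(=O)C1=Cc2ccccc2OC1(OCc1cn(-c2ccccc2)nn1)C(F)(F)F`: > 150000 nM
Compound 2 `CCOC(=O)C1=Cc2ccccc2OC1(OCc1cn(-c2ccc(F)c([N+](=O)[O-])c2)nn1)C(F)(F)F`: 13200 nM
Compound 3 `CCOC(=O)C1=Cc2ccccc2OC1(OCc1cn(CC(=O)Nc2cccc(F)c2)nn1)C(F)(F)F`: > 150000 nM

All three compounds share one core and differ only in the group carried on an aromatic nitrogen of the five-membered ring. In a functional assay on DU-145 cells (Homo sapiens) for inhibition, read by MTT assay, with a stated time of 24 h (on this read-out higher numbers stand for weaker inhibition and lower numbers for stronger inhibition), compound 2 gives 13200 nM. For compound 1 the read-out is only a limit, > 150000 nM, not a number. Compound 3 likewise gives only a limit, > 150000 nM. Where compound 3 stands is therefore marked by the limit of > 150000 nM in this assay, at which 2 of the 3 values shown sit.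

Compound 4 `CCOC(=O)C1=Cc2ccccc2OC1(OCc1cn(-c2ccc(C)cc2)nn1)C(F)(F)F` is not yet measured. The change from compound 3 is 4-methylphenyl in place of ((3-fluorophenyl)carbamoyl)methyl on an aromatic nitrogen. For the measured compounds named here, two measured steps touch this kind of exchange. an at least 11-fold higher number from compound 2 to compound 3 (1.05 log units; beyond the scatter) shows that swapping an aromatic ring for the carbamoylmethyl chain weakened inhibition strongly. Returning to an aromatic ring in compound 4 points the other way, but a step that the two limits leave unreadable from compound 1 to compound 3 is unreadable, and the closer relative compound 1, with a plain phenyl, sits at the limit. The 4-methylphenyl of compound 4 resembles the phenyl of compound 1 more than the nitro-bearing ring of compound 2, so a limit is expected again, and the expected step is an at least 1.2-fold lower number from compound 3 to compound 4 (0.09 log units; that floor lies within the scatter). Compound 4 is expected at 120000 nM, between 30000 nM and 300000 nM.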

Compound 4, half-maximal inhibitory concentration: 30200 nM
Estimate against measurement, compound 4: 4.0-fold (0.60 log units) above; measured number inside the range.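

In this assay, adding one methyl to the plain phenyl gives an at least 4.9-fold lower number from compound 1 to compound 4 (0.69 log units; beyond the scatter), so the ring on the aromatic nitrogen does not need a nitro group to produce a measurable value. Exchanging the 4-fluoro-3-nitrophenyl ring for 4-methylphenyl gives a 2.3-fold higher number from compound 2 to compound 4 (0.36 log units; beyond the scatter), which shows that the gap between these two substituted rings is far smaller than the gap that separates the plain phenyl from the nitro-bearing ring. Exchanging the ((3-fluorophenyl)carbamoyl)methyl chain for 4-methylphenyl gives an at least 4.9-fold lower number from compound 3 to compound 4 (0.69 log units; beyond the scatter), so both substituted rings set directly on the aromatic nitrogen outperform that chain, although the plain phenyl of compound 1 does not share this pattern.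

As far as these compounds go, the steps that start from compound 1 and compound 3 give only a minimum size, and their full size stays unknown: the limit of > 150000 nM in this assay, at which 2 of the 4 values shown sit. From the compounds shown here alone, it also remains open whether another small group on the ring, such as the chlorine of 4-chlorophenyl, the methoxy of 4-methoxyphenyl or the amine of 4-aminophenyl, would match the methyl or the combined fluorine and nitro groups.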